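Norepinephrine transporter binding: ester chain extension in compound 3

A few compounds are considered here, and "the series" means these few. Any claim that something is new, unique, unknown or untested is made for them only; others in the source may bear on it.

Measured compounds:
- compound 1 `Clc1ccc([C@@H]2CCN3C/C(=N\OCCCc4ccccc4)C2C3)cc1`: 483 nM
- compound 2 `CN1CCC(c2ccc(Cl)cc2)C(C(=O)OCCCc2ccccc2)C1`: 72 nM

In an assay on a subcellular fraction from brain for binding affinity to Norepinephrine transporter (Rattus norvegicus) (a higher number here means a weaker inhibitor, a lower number a stronger inhibitor), compound 1 gives 483 nM. In this assay compound 2 gives 72 nM, the lower of the two numbers; the gap between compound 1 and compound 2 lies beyond the usual scatter, so compound 2 is the stronger inhibitor of the pair. The two structures differ in several places at once, so no single structural cause can be attached to that gap.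

Compound 3 `CN1CCC(c2ccc(Cl)cc2)C(C(=O)OCCCCCc2ccccc2)C1` is the next member of the series. It differs from compound 2 in one place: phenethyl in place of phenyl on a saturated chain carbon, three bonds along the chain from an oxygen next to a carbonyl group. The ester carbonyl, the basic ring and the chloro-substituted aryl group of compound 2 are kept unchanged.

Going by the values given here, no measured pair in this set shows the effect of lengthening the chain between the ester oxygen and the aromatic ring, so the size of the step from compound 2 to compound 3 in this assay is uncertain. The expectation is a small step, at most at the edge of the scatter, with a slight lean towards a higher number, as a 1.5-fold higher number from compound 2 to compound 3 (0.18 log units; within the scatter). For compound 3 the expected value in this assay is 110 nM, within a range from 30 nM to 400 nM.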

Compound 3, inhibition constant: 382 nM
Beside the measured number, compound 3's estimate is 3.5-fold (0.54 log units) below it; the measured number falls inside the stated range.
By their numbers in this assay, from the lowest: compound 2; then compounds 3 and 1 (each within the scatter of the next).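

In this assay, going by these compounds alone, the change of phenyl to phenethyl on a saturated chain carbon, three bonds along the chain from an oxygen next to a carbonyl group, gives a 5.3-fold higher number from compound 2 to compound 3 (0.72 log units; beyond the scatter) and is the first single-place step that can be read. It shows that this position is sensitive to chain length: the same difference, read as benzyl to 3-phenylpropyl, leaves compound 3 a weaker inhibitor than compound 2, with the remainder of the structure unchanged. Nothing available accounts for this loss in binding.

On these data alone, one step fixes neither the direction nor the shape of the trend along the chain, so whether a shorter chain than that of compound 2 gives a lower number remains open, as does whether the rise continues with a longer chain than that of compound 3. Also open, as far as these compounds go, is whether the step from compound 2 to compound 3 would hold with an amide in place of the ester.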